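The compounds below may be only part of what the source reports. "The series", "measured", "known", "first", "only" and "open" are said of these compounds alone.

Measured in a functional assay on isolated protein for inhibition of Glucose-dependent insulinotropic receptor (Homo sapiens), read by HTRF and cAMP accumulation; on this read-out lower numbers stand for an effect already at smaller amounts and higher numbers for an effect only at larger amounts of compound:
compound 1 `Cc1nc(S(C)(=O)=O)ccc1Oc1ncnc(OC2CCN(C(=O)OC(C)F)CC2)c1F` gives 65.5 nM;
compound 2 `Cc1nc(S(C)(=O)=O)ccc1Oc1ncnc(OC2CCN(C(=O)C(C)(C)F)CC2)c1F` gives 76.3 nM;
compound 3 `Cc1nc(S(C)(=O)=O)ccc1Oc1ncnc(OC2CCN(C(=O)c3noc(C(C)(C)F)n3)CC2)c1F` gives 14 nM.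

Compound 3 has the lowest number of the three, set apart from compound 1 by a 4.7-fold lower number from compound 1 to compound 3 (0.67 log units; beyond the scatter) and from compound 2 by a 5.5-fold lower number from compound 2 to compound 3 (0.74 log units; beyond the scatter). Compound 4 `CCc1cnc(C(=O)N2CCC(Oc3ncnc(Oc4ccc(S(C)(=O)=O)nc4C)c3F)CC2)nc1` differs from compound 3 by a group of 8 heavy atoms (6 carbon, 2 nitrogen; one six-membered aromatic ring with 2 hetero atoms) in place of a group of 9 heavy atoms (5 carbon, 2 nitrogen, 1 oxygen, 1 fluorine; one five-membered aromatic ring with 3 hetero atoms), on a carbonyl carbon. The two measured steps onto this carbonyl carbon both exchanged a short chain for the five-membered aromatic ring; no measured step exchanges one aromatic ring for another, so the direction of the present change is not shown. Compound 4 is therefore expected near compound 3, with a 1.4-fold higher number from compound 3 to compound 4 (0.15 log units; within the scatter) as the estimated step, giving an expected 20 nM within 6 nM to 65 nM in this assay.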

Compound 4, half-maximal effective concentration: 4.7 nM
Compound 4: middle estimate off by 4.3-fold (0.63 log units), on the high side; measured number below the stated range.
By their numbers in this assay, from the lowest: compound 4; then compound 3; then compounds 1 and 2 (each within the scatter of the next).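

On this carbonyl carbon, exchanging one aromatic ring for another still moves the number: in this assay, 5-ethylpyrimidin-2-yl in place of the five-membered ring gives a 3.0-fold lower number from compound 3 to compound 4 (0.47 log units; beyond the scatter). Measured against the ring-free groups, the same 5-ethylpyrimidin-2-yl gives a 16-fold lower number from compound 2 to compound 4 (1.21 log units; beyond the scatter) and a 14-fold lower number from compound 1 to compound 4 (1.14 log units; beyond the scatter), both larger than any earlier step. Nothing measured here explains these steps.

As far as these compounds go, whether the ring or its ethyl carries the effect stays open. A methyl or propyl chain on the same ring, or a phenyl ring instead, would help separate the two.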